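The compounds below may be only part of what the source reports. "The series", "measured", "known", "first", "only" and "open" are said of these compounds alone.

In a functional assay on LoVo cells (Homo sapiens) for inhibition, read by MTT assay, with a stated time of 24 h (on this read-out higher numbers stand for weaker inhibition and lower numbers for stronger inhibition), compound 1 `CC1(C)[C@H]2CC[C@]1(C)N(Cc1cn(-c3ccccc3F)nn1)C(=O)C2` gives 40 nM, compound 2 `CC1(C)[C@H]2CC[C@]1(C)N(Cc1cn(-c3ccc(Br)cc3)nn1)C(=O)C2` gives 60 nM, and compound 3 `Cc1ccc(-n2cc(CN3C(=O)C[C@@H]4CC[C@@]3(C)C4(C)C)nn2)cc1` gives 50 nM. Compound 3 therefore stands level with the other two: a 1.3-fold higher number from compound 1 to compound 3 (0.10 log units; within the scatter) and a 1.2-fold lower number from compound 2 to compound 3 (0.08 log units; within the scatter) both lie within the scatter.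

Compound 4 `CC1(C)[C@H]2CC[C@]1(C)N(Cc1cn(-c3ccccc3O)nn1)C(=O)C2` carries 2-hydroxyphenyl in place of 4-methylphenyl on an aromatic nitrogen. The measured steps that bear on this are swaps of the group at that same nitrogen. Besides the two above, there is a 1.5-fold higher number from compound 1 to compound 2 (0.18 log units; within the scatter), which is also within the scatter. Across these three compounds, then, changing this group has not moved the number measurably. Among the compounds with values here, that pattern rests on only three compounds, and none of them carries a hydroxy group, so the new group is untested and the range must stay wide.

The estimated step is no change at the digits printed from compound 3 to compound 4 (within the scatter), so no change beyond the scatter is expected. For compound 4 the expected value is 50 nM, with an estimated range from 15 nM to 170 nM.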

Compound 4, half-maximal inhibitory concentration: 540 nM
The estimate for compound 4 lay 11-fold (1.03 log units) below the measured number; the measured number lies above the stated range.
By their numbers in this assay, from the lowest: compounds 1, 3 and 2 (each within the scatter of the next); then compound 4.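

The group on this aromatic nitrogen is less free to change than the first three compounds suggested: 2-hydroxyphenyl gives an 11-fold higher number from compound 3 to compound 4 (1.03 log units; beyond the scatter) and a 9.0-fold higher number from compound 2 to compound 4 (0.95 log units; beyond the scatter), and on this read-out a higher number means weaker inhibition. The closest comparison is hydroxy in place of fluoro on an aromatic carbon, with the rest of the molecule unchanged, which gives a 14-fold higher number from compound 1 to compound 4 (1.13 log units; beyond the scatter), so this one replacement is enough to weaken inhibition clearly. The data shown offer no measurement that explains this loss.

From the compounds shown here alone, it remains open whether the hydroxy group would have the same effect elsewhere on the phenyl ring. Going by these compounds, it is also open whether a methoxy group or an amine in its place would give a number close to that of compound 1 or to that of compound 4.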